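Swapping the Phenol for a Dimethylaminophenyl Group

The compounds below may be only part of what the source reports. "The series", "measured", "known", "first", "only" and "open" are said of these compounds alone.

The series shares one core and was tested in a functional assay on cells (Cancer cell lines, Homo sapiens) for cytotoxicity, read by sulforhodamine B assay, with a stated time of 48 h; on this read-out lower numbers stand for stronger inhibition of growth and higher numbers for weaker inhibition of growth. Compound 1 `O=C1N=C(N2N=C(c3ccccc3)CC2c2ccccc2O)S/C1=C1/C(=O)Nc2ccccc21` gives 2070 nM in this assay. Going by the values given here, compound 2 `O=C1N=C(N2N=C(c3ccccc3)CC2c2ccccc2O)S/C1=C1/C(=O)Nc2ccc(Br)cc21`, which carries a bromo in place of hydrogen on an aromatic carbon, gives 230 nM; that step, a 9.0-fold lower number from compound 1 to compound 2 (0.95 log units; beyond the scatter), is the only single-point comparison available. Compound 3 `Cc1ccc2c(c1)/C(=C1\SC(N3N=C(c4ccccc4)CC3c3ccc(Cl)cc3)=NC1=O)C(=O)N2` gives 240 nM, a number within the scatter of compound 2, even though compound 3 differs from compound 2 in two places at once. Among the three measured numbers, compound 2 stands at the lowest, with compound 3 indistinguishable from it and compound 1 clearly higher.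

Compound 4 `CN(C)c1ccc(C2CC(c3ccccc3)=NN2C2=NC(=O)/C(=C3\C(=O)Nc4ccc(Br)cc43)S2)cc1` is not yet measured. Its change from compound 2 is 4-(dimethylamino)phenyl in place of 2-hydroxyphenyl on a saturated ring carbon. Among the compounds with values here, no measured step touches this saturated ring carbon alone, so the step from compound 1 to compound 2, which concerns a different position, does not bear on it directly. Within the data shown here, the only hint is that compound 3, which also carries a different group at this carbon, gives a number close to compound 2. The expected step is therefore a 1.3-fold higher number from compound 2 to compound 4 (0.12 log units; within the scatter), within the scatter. The estimate for compound 4 is 300 nM, expected to fall between 100 nM and 900 nM.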

Compound 4, concentration for 50% growth inhibition: 200 nM
Compound 4: the middle estimate sits 1.5-fold (0.18 log units) above what was measured; low and high end bracket the measured number.
By their numbers in this assay, from the lowest: compounds 4, 2 and 3 (each within the scatter of the next); then compound 1.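

Going by these compounds alone, this is the first single-place comparison at the saturated ring carbon, and in this assay the move to 4-(dimethylamino)phenyl from 2-hydroxyphenyl gives a 1.2-fold lower number from compound 2 to compound 4 (0.06 log units; within the scatter), so the two compounds cannot be told apart. In this bromo-bearing pair, then, the position accepts a group of 9 heavy atoms in place of one of 7, and the hydrogen-bond donor of the 2-hydroxyphenyl group can be absent without a readable difference in growth inhibition. No accompanying measurement bears on this result, so the data offer no explanation for it.

The swap alters the group on the phenyl ring and its location in a single step, so the separate contributions of the hydroxyl, the dimethylamino group and their locations on that ring remain unresolved. Also open, on these data alone, are whether an unsubstituted phenyl, a carboxylic acid or a morpholine on this ring would fit as well, and whether 4-(dimethylamino)phenyl would behave the same way on the core of compound 1, which lacks the bromo.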